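Chloro to Methyl on the Shared Core

The source may hold more compounds than are shown below. What is called first, only, known or untested is meant among the compounds shown, and "the series" means these compounds.

compound 1 `COc1ccc(-c2cc(Cl)cc(C(=O)Nc3nn[nH]n3)n2)cc1`: 100%
compound 2 `CCc1ccc(-c2cc(Cl)cc(C(=O)Nc3nn[nH]n3)n2)cc1`: 100%

In a functional assay on the whole organism with Rattus norvegicus as the target, at a dose of 3 mg/kg by the oral route (on this read-out higher numbers stand for a stronger effect at the one dose given and lower numbers for a weaker effect), compound 1 gives 100%, and compound 2 gives 100%, so compound 1 stands level with compound 2; the step of no change at the digits printed from compound 1 to compound 2 (within the scatter) shows that exchanging methoxy for ethyl left the read-out unchanged. Compound 3 `COc1ccc(-c2cc(C)cc(C(=O)Nc3nn[nH]n3)n2)cc1` differs from compound 1 by methyl in place of chloro on an aromatic carbon. For the measured compounds named here, no measured step touches this position on the shared core, so nothing bears directly on it. With compound 1 at the ceiling of this read-out, the expected step is a number 5 percentage points lower from compound 1 to compound 3 (within the scatter), none beyond the scatter. Compound 3 is therefore estimated at 95%, within 78% to 100%.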

Compound 3, a percentage reported as inhibition, in the whole organism at one dose (the size of the read-out at that dose, not a potency): 43%
For compound 3 the middle estimate is 52 percentage points above the measured one, outside the stated range (below it).
By their numbers in this assay, from the lowest: compound 3; then compounds 1 and 2 (each within the scatter of the next).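

In this assay, methyl in place of chloro on the aromatic carbon opposite the ring nitrogen gives a number 57 percentage points lower from compound 1 to compound 3 (beyond the scatter), whereas ethyl in place of methoxy gave no change at the digits printed from compound 1 to compound 2 (within the scatter). This position therefore responds strongly on this read-out, and the chloro cannot be exchanged for methyl here without a clear loss of effect at this dose. Nothing at hand accounts for this loss. Going by these compounds, whether bromo, fluoro, a nitrile or an amine at this position would keep the effect remains open, as does whether the same step would appear with ethyl in place of methoxy.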